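Chloro position on the amide aryl across two thioester cores

This account rests on a few compounds, and the source may have more. Where it says the series, first, only, none or still open, it means among the compounds named here.

Measured compounds:
compound 1, `CC(=O)SCCC(CCCCC(=O)Nc1cccc(Cl)c1)SC(C)=O`, 38.2%
compound 2, `CC(=O)SCCC(CCCCC(=O)Nc1ccc(Cl)cc1)SC(C)=O`, 58.8%
compound 3, `O=C(CCCCC(CCSC(=O)c1ccccc1)SC(=O)c1ccccc1)Nc1cccc(Cl)c1`, "not active" (no number reported), without a number

The study compares two pairs of anilides carrying a bis-thioester side chain, tested in a functional assay on HO8910 cells (Homo sapiens) for inhibition, read by MTT assay, with a stated time of 24 h, tested at 100 ug/mL; a lower number here means less inhibition of growth, a higher number more inhibition of growth at the concentration tested. Compound 1 `CC(=O)SCCC(CCCCC(=O)Nc1cccc(Cl)c1)SC(C)=O` gives 38.2%, and compound 2 `CC(=O)SCCC(CCCCC(=O)Nc1ccc(Cl)cc1)SC(C)=O` gives 58.8%; the change between them, (4-chlorophenyl in place of 3-chlorophenyl on an amide-type nitrogen), is a step of a number 20.6 percentage points higher from compound 1 to compound 2 (beyond the scatter).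

Compound 3 `O=C(CCCCC(CCSC(=O)c1ccccc1)SC(=O)c1ccccc1)Nc1cccc(Cl)c1` carries a different core; how that core differs from the core of compound 1 is not broken down here. Compound 3 was reported as "not active" (no number reported) in this assay, with no number given. Compound 4 `O=C(CCCCC(CCSC(=O)c1ccccc1)SC(=O)c1ccccc1)Nc1ccc(Cl)cc1` differs from compound 3 by 4-chlorophenyl in place of 3-chlorophenyl on an amide-type nitrogen, the same change as from compound 1 to compound 2, at the same place.

Since compound 3 gave no number, the step from compound 3 to compound 4 cannot be measured against the earlier one. If the earlier step carries over, compound 4 is expected to lie above an inactive starting point, and its value in this assay is estimated at 20%, with a range from 0% to 45%.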

Compound 4, percent growth inhibition at one concentration: "not active" (no number reported)
Compound 4: no number reported; the estimate stays without a comparison.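

In this assay compound 3 is reported as "not active" (no number reported) and compound 4 as "not active" (no number reported), so no step can be read between them. The compounds shown leave open whether 4-chlorophenyl in place of 3-chlorophenyl changes growth inhibition on the core of compound 3 as it does on the core of compound 1. Nothing shown here offers an explanation for this result.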